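Benzyl ether series: nitro replaced by trifluoromethyl

The source may report more compounds than this note shows. Statements on the series, on what has been measured and on what is new or still open speak of the compounds shown alone.

Measured in a functional assay on A-375 cells (Homo sapiens) for antiproliferative activity, read by MTT assay, with a stated time of 24 h; on this read-out higher numbers stand for weaker inhibition and lower numbers for stronger inhibition:
compound 1 `COc1cc(OC)c(-c2coc3cc(OCC=C(C)C)ccc3c2=O)cc1OC` gives 1580 nM.
compound 2 `COc1cc(OC)c(-c2coc3cc(OCc4ccccc4)ccc3c2=O)cc1OC` gives 1640 nM.
compound 3 `COc1cc(OC)c(-c2coc3cc(OCc4ccc([N+](=O)[O-])cc4)ccc3c2=O)cc1OC` gives > 10000 nM, which is a limit of the assay and not a number.

Compound 3 therefore stands as the weakest of the three: the step of an at least 6.3-fold higher number from compound 1 to compound 3 (0.80 log units; beyond the scatter) and the step of an at least 6.0-fold higher number from compound 2 to compound 3 (0.78 log units; beyond the scatter) both lie beyond the scatter, whereas a 1.0-fold higher number from compound 1 to compound 2 (0.02 log units; within the scatter) does not. Compound 4 `COc1cc(OC)c(-c2coc3cc(OCc4ccc(C(F)(F)F)cc4)ccc3c2=O)cc1OC` carries trifluoromethyl in place of nitro on an aromatic carbon. Among the compounds with values here, only an at least 6.0-fold higher number from compound 2 to compound 3 (0.78 log units; beyond the scatter) bears on this carbon, and it shows the number rising when nitro enters in place of hydrogen; trifluoromethyl is neither group, so no measured step fixes the size of the new step. A partial return toward compound 2 is expected, the step of an at least 2.0-fold lower number from compound 3 to compound 4 (0.30 log units; that floor lies within the scatter) being estimated as a fall in the number, with a limit still possible. Compound 4 is expected at 5000 nM, in the range 1500 nM to 20000 nM.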

Compound 4, half-maximal inhibitory concentration: 2280 nM
Compound 4: middle estimate off by 2.2-fold (0.34 log units), on the high side; the range from low to high includes it.
By their numbers in this assay, from the lowest: compounds 1, 2 and 4 (each within the scatter of the next). At a limit, above all of these: compound 3.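

In this assay, trifluoromethyl in place of nitro on this aromatic carbon gives an at least 4.3-fold lower number from compound 3 to compound 4 (0.64 log units; beyond the scatter), so the rise seen with nitro does not extend to every group placed here. Trifluoromethyl in place of hydrogen gives a 1.4-fold higher number from compound 2 to compound 4 (0.14 log units; within the scatter), and the comparison with the 2-methylprop-1-en-1-yl ether gives a 1.4-fold higher number from compound 1 to compound 4 (0.16 log units; within the scatter), so neither step separates compound 4 from these two compounds. The step from nitro is only a floor, with compound 3 held at a limit and not a number: the limit of > 10000 nM in this assay, at which 1 of the 4 values shown sits.

Going by these compounds, what sets nitro apart from trifluoromethyl stays open. On these data alone, whether an amine or a carboxylic acid on this carbon would follow nitro or trifluoromethyl also stays open.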